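The source may report more compounds than this note shows. Statements on the series, on what has been measured and on what is new or still open speak of the compounds shown alone.

Measured compounds in a functional assay on A549 cells (Homo sapiens) for antiproliferative activity, read by MTT assay, with a stated time of 72 h; on this read-out higher numbers stand for weaker inhibition and lower numbers for stronger inhibition: compound 1 `c1ccc(COc2ccccc2Nc2ncnc3cc4c(cc23)OCCOCCOCCO4)cc1` gives 6940 nM. Compound 2 `FC(F)(F)c1ccc(COc2ccccc2Nc2ncnc3cc4c(cc23)OCCOCCOCCO4)cc1` sits at the limit of the assay, > 100000 nM. Compound 3 `O=[N+]([O-])c1ccc(COc2ccc(Nc3ncnc4cc5c(cc34)OCCOCCOCCOCCO5)cc2)cc1` likewise returns only a limit, > 100000 nM.

Compound 2 therefore stands at the top of the numbers shown, with no value of its own; it shares the limit with compound 3 (the limit of > 100000 nM in this assay, at which 2 of the 3 values shown sit). For the measured compounds named here, the one measured step that reaches it, an at least 14-fold higher number from compound 1 to compound 2 (1.15 log units; beyond the scatter), is large and beyond the scatter.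

Compound 4 `O=[N+]([O-])c1ccc(COc2ccccc2Nc2ncnc3cc4c(cc23)OCCOCCOCCO4)cc1` is the next case: nitro in place of trifluoromethyl on an aromatic carbon. Going by the values given here, no measured step covers this exchange directly. Compound 3 carries the same nitro group and also returns only a limit, but it differs from compound 4 in more than one place, so only its value can be read, not a step. The step of an at least 14-fold higher number from compound 1 to compound 2 (1.15 log units; beyond the scatter) shows that this position tolerates a change poorly, with nothing to suggest a return toward compound 1.

The expected step of a number no higher from compound 2 to compound 4 (the limit leaves the size open) is none beyond the scatter, with compound 4 expected to stay at or near the limit. The estimate for compound 4 is 100000 nM, within 30000 nM to 300000 nM.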

Compound 4, half-maximal inhibitory concentration: 29900 nM
Estimate against measurement, compound 4: 3.3-fold (0.52 log units) above, and the stated range ends above it.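

Trifluoromethyl and nitro do not behave alike at this place: in this assay, 4-nitrobenzyl gives a readable number, with an at least 3.3-fold lower number from compound 2 to compound 4 (0.52 log units; beyond the scatter). Compound 2 remains a limit of the assay at > 100000 nM, so this step has no upper bound on its size. The position therefore does not lose all measurable activity with every group larger than hydrogen, although nitro still weakens inhibition, with a 4.3-fold higher number from compound 1 to compound 4 (0.63 log units; beyond the scatter).

On these data alone, with only hydrogen, trifluoromethyl and nitro on this aromatic carbon, it remains open whether every replacement of hydrogen weakens inhibition, which an amine or a carboxylic acid at the same place would help to settle. As far as these compounds go, compound 3 differs from compound 4 in more than one place, so no step can be read between them, and the effect of its different chain remains open.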